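A few compounds are considered here, and "the series" means these few. Any claim that something is new, unique, unknown or untested is made for them only; others in the source may bear on it.

Of the compounds shown here, three sharing one core have been measured in an assay on isolated protein for inhibition of aldehyde dehydrogenase 1A1 (Homo sapiens), read by spectrophotometry, tested at 10 uM; a higher number here means more inhibition at the concentration tested (going by the name of the read-out), a lower number less inhibition. Compound 1 `Cc1cccc(Cn2c(CN3CCN(C(=O)c4ccc([N+](=O)[O-])cc4)CC3)nc3ccccc32)c1` gives 24.3% in this assay. Compound 2 `O=C(C1CC1)N1CCN(Cc2nc3ccccc3n2Cc2ccccc2)CC1` gives 23.9%, and compound 3 `CCCCn1c(CN2CCN(C(=O)C3CC3)CC2)nc2ccccc21` gives 18.2%. Both of these numbers lie within the usual scatter of the number of compound 1, so the three measured compounds cannot be told apart in this assay. For the measured compounds named here, the only measured step between two compounds that differ in a single place is a number 5.7 percentage points lower from compound 2 to compound 3 (within the scatter), a change at the saturated chain carbon bound to the aromatic nitrogen.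

Compound 4 `CCCC(=O)N1CCN(Cc2nc3ccccc3n2Cc2cccc(C)c2)CC1` has not yet been measured. It differs from compound 1 by propyl in place of 4-nitrophenyl on a carbonyl carbon. Going by the values given here, no measured pair shows this exchange on the carbonyl carbon, so no step bears on it directly; the step from compound 2 to compound 3 concerns a different place and stayed within the scatter, and compounds 2 and 3 give numbers within the scatter of compound 1. The account therefore expects for compound 4 no step beyond the scatter, a number 3.3 percentage points lower from compound 1 to compound 4 (within the scatter). The estimated value of compound 4 in this assay is 21%, with a range from 8% to 34%.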

Compound 4, a percentage reported as inhibition, at one concentration (the size of the read-out at that concentration, not a potency): 79.1%
Estimate against measurement, compound 4: 58.1 percentage points below; the measured number lies above the stated range.
By their numbers in this assay, from the lowest: compounds 3, 2 and 1 (each within the scatter of the next); then compound 4.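

In this assay, the exchange on the carbonyl carbon gives a number 54.8 percentage points higher from compound 1 to compound 4 (beyond the scatter), the only listed step that lies beyond the scatter, so this position responds in a way the earlier compounds gave no sign of. For the compounds shown here, the one earlier step, a number 5.7 percentage points lower from compound 2 to compound 3 (within the scatter), concerned the saturated chain carbon bound to the aromatic nitrogen and stayed within the scatter. Here, 4-nitrophenyl, with its aromatic ring and 9 heavy atoms, gives way to propyl, an open chain of 3 carbons, and no information in hand explains the size of this step.

As far as these compounds go, it remains open whether the higher number follows from the presence of propyl or simply from the loss of 4-nitrophenyl, and whether an unsubstituted phenyl, a butyl chain or an isopropyl group on the same carbonyl carbon would stay near the value of compound 4, 79.1%. Also open, from the compounds shown here alone, is whether propyl on this carbonyl carbon would give a similar step with a different group on the aromatic nitrogen, such as the butyl chain of compound 3.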